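Single stereocentre on the carbamoylazetidine: compound 3 expected

The source may hold more compounds than are shown below. What is called first, only, known or untested is meant among the compounds shown, and "the series" means these compounds.

Compound 1 `NC(=O)C1CCN1Cc1ccc(OCc2cccc(F)c2)cc1` gives 18000 nM in an assay on Sf9 cells for inhibition of Amine oxidase [flavin-containing] A (Homo sapiens), with stated times of 15 min and 60 min; a lower number here means a stronger inhibitor, a higher number a weaker inhibitor.
Compound 2 `NC(=O)C1CN(Cc2ccc(OCc3cccc(F)c3)cc2)C1` gives > 10000 nM in this assay, which is a limit of the assay, not a number.

Compound 2 therefore stands only at a limit in this assay; where it lies beyond that is not known. Within the data shown here, the one measured step, a step that the limit leaves unreadable from compound 1 to compound 2, is itself unreadable for the same reason, as the limit of > 10000 nM in this assay, at which 1 of the 2 values shown sits, records. Compound 3 `NC(=O)[C@@H]1CCN1Cc1ccc(OCc2cccc(F)c2)cc1` is now to be measured. It differs from compound 2 as follows: 2-carbamoylazetidin-1-yl in place of 3-carbamoylazetidin-1-yl on a saturated chain carbon bound to an aromatic carbon. Among the measured compounds shown here, this change runs back toward the group carried by compound 1, so the only bearing step is the reverse of the unreadable step from compound 1 to compound 2, and its size cannot be taken from the data. The expectation for compound 3 is therefore anchored on compound 1 alone, with room on either side for the effect of the single defined stereocentre. Compound 3 is estimated at 12000 nM, within 4000 nM to 40000 nM, and the step from compound 2 expected is a step that the limit leaves unreadable from compound 2 to compound 3.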

Compound 3, half-maximal inhibitory concentration: 26800 nM
Compound 3: middle estimate off by 2.2-fold (0.35 log units), on the low side, within the range that was stated.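

In this assay, among these compounds, the one readable new comparison is a 1.5-fold higher number from compound 1 to compound 3 (0.17 log units; within the scatter), so the 2-carbamoylazetidin-1-yl group drawn as S and the same group drawn without a configuration cannot be told apart here. At this saturated ring carbon, therefore, fixing the drawn configuration as S brings no separation from the undefined form, and the two compounds share all their atoms and bonds, so the comparison concerns that one feature alone: the fact that one of compounds 1 and 3 is drawn with a defined configuration and the other without, at the place where they differ Compound 2 still stands only at a limit, so neither step between the 3-carbamoylazetidin-1-yl and 2-carbamoylazetidin-1-yl groups can be read, in either direction, and the effect of moving the carbamoyl group on the ring remains without a size: the limit of > 10000 nM in this assay, at which 1 of the 3 values shown sits.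

As far as these compounds go, what remains open is how the R form of the 2-carbamoylazetidin-1-yl group would read in this assay, and whether compound 2 would differ from compound 3 if it carried a number rather than a limit. Also open, from the compounds shown here alone, is how a carboxylic acid or an amine in place of the carbamoyl group on the four-membered ring would read in this assay.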